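From compound 1 to compound 3: a pyrrolidine replacement

A few compounds are considered here, and "the series" means these few. Any claim that something is new, unique, unknown or untested is made for them only; others in the source may bear on it.

Working notes on the series. In a functional assay on HepG2 cells (Homo sapiens) for inhibition, read by MTT assay, with a stated time of 3 days (a lower number here means a stronger inhibitor, a higher number a weaker inhibitor), compound 1 `COc1cc(-c2nc3ccccc3s2)ccc1OCC(=O)NNC(=O)CN[C@@H](CS)C(=O)O` gives 3120 nM and compound 2 `COc1cc(-c2nc3ccccc3s2)ccc1OCC(=O)NNC(=O)CNC(=N)NCCC[C@H](N[N+](=O)[O-])C(=O)O` gives 3490 nM and the two stand level, within the scatter of each other. Compound 1 therefore has no measured lead or lag in this small set.

Compound 3 `COc1cc(-c2nc3ccccc3s2)ccc1OCC(=O)NNC(=O)CN1CCC[C@H]1C(=O)O` keeps the core of compound 1 and carries 2-carboxypyrrolidin-1-yl in place of (1-carboxy-2-sulfanylethyl)amino on a saturated chain carbon bound to a carbonyl carbon, the counted change being 2-carboxypyrrolidin-1-yl in place of (1-carboxy-2-sulfanylethyl)amino on a saturated chain carbon bound to a carbonyl carbon at that one place.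

Going by the values given here, no measured pair differs in one place only, so no step offers a direct guide. In this assay no step beyond the scatter is expected, in either direction, and this expectation is anchored on compound 1 at 3120 nM as the starting point. The estimate for this change is a 1.1-fold higher number from compound 1 to compound 3 (0.05 log units; within the scatter) and it is expected to stay within the scatter. In this assay the expected value for compound 3 is 3500 nM with an estimated range from 1500 nM to 8000 nM for that measurement.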

Compound 3, half-maximal inhibitory concentration: 2650 nM
Estimate against measurement, compound 3: 1.3-fold (0.12 log units) above, within the range that was stated.
By their numbers in this assay, from the lowest: compounds 3, 1 and 2 (each within the scatter of the next).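

In this assay, going by these compounds alone, 2-carboxypyrrolidin-1-yl in place of (1-carboxy-2-sulfanylethyl)amino on a saturated chain carbon bound to a carbonyl carbon gives a 1.2-fold lower number from compound 1 to compound 3 (0.07 log units; within the scatter), and this is the first pair that differs in one place only. At this position, therefore, the sulfur atom and the open chain of compound 1 can give way to a five-membered non-aromatic ring with no step beyond the scatter, while the carboxy group and a defined stereocentre are present on both sides of the exchange. No measurement bears on why the number holds level across this change.

Since both groups carry the carboxy group, the step says nothing about what that group contributes, and plain pyrrolidin-1-yl or a primary amide in its place would be needed to address this. Also open, from the compounds shown here alone, is whether the level result holds for the opposite stereocentre in the pyrrolidine ring or for a six-membered piperidine ring carrying the same carboxylic acid.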